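The source may hold more compounds than are shown below. What is called first, only, known or untested is meant among the compounds shown, and "the series" means these compounds.

Measured so far:
compound 1, `COc1ccccc1CN(C)C(=O)Nc1c(-c2ccccc2)c2cc(C)c(C)cc2c(=O)n1C`, 23 nM
compound 2, `CN(Cc1ccccc1Cl)C(=O)Nc1c(-c2ccc(F)cc2)c2ccccc2c(=O)n1C`, 480 nM
compound 3, `CN(Cc1cc(C(F)(F)F)cc(C(F)(F)F)c1)C(=O)c1c(-c2ccccc2)c2cccnc2c(=O)n1C`, 0.25 nM

In an assay on IM-9 cells for binding affinity to Substance-P receptor (Homo sapiens) (a higher number here means a weaker inhibitor, a lower number a stronger inhibitor), compound 1 stands second highest of the three numbers. Among the measured compounds shown here, compound 2 gives a higher number than compound 1, beyond the scatter, and compound 3 gives a far lower number, also beyond the scatter; neither pair is a single change, so no step is read from them.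

Compound 4 is `Cc1cc2c(-c3ccccc3)c(NC(=O)N(C)Cc3ccccc3Cl)n(C)c(=O)c2cc1C`. Against compound 1 the change is chloro in place of methoxy on an aromatic carbon. For the measured compounds named here, no measured pair isolates this change. Compound 2 carries the chloro group on a different core and sits high in this assay, which counts lightly toward weaker binding. A small step is expected, toward a higher number, possibly within the scatter: a 2.2-fold higher number from compound 1 to compound 4 (0.34 log units; beyond the scatter). Compound 4 is estimated at 50 nM, range 15 nM to 200 nM.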

Compound 4, half-maximal inhibitory concentration: 4.2 nM
The estimate for compound 4 lay 12-fold (1.08 log units) above the measured number; the whole stated range lies above it.
By their numbers in this assay, from the lowest: compound 3; then compound 4; then compound 1; then compound 2.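

In this assay, among the compounds shown here, 2-chlorobenzyl in place of 2-methoxybenzyl gives a 5.5-fold lower number from compound 1 to compound 4 (0.74 log units; beyond the scatter), the first step read from a single change. The group on this aromatic carbon, ortho to a large group, therefore bears on the number, and the hydrogen-bond acceptor that leaves with methoxy is not needed for a value this low. Nothing measured here accounts for the step.

Open, as far as these compounds go, is how a bromo or a nitrile at this carbon would compare with chloro. Also open, from the compounds shown here alone, is whether the step carries over to other cores.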